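Dropping the (Carboxymethyl)amino Group Before Cytotoxicity Is Known

The source may hold more compounds than are shown below. What is called first, only, known or untested is meant among the compounds shown, and "the series" means these compounds.

The study measures cytotoxicity in an ADME assay on MRC5 cells (Homo sapiens) for cytotoxicity, read by MTT assay, with a stated time of 72 h; a higher number here means a weaker inhibitor, a lower number a stronger inhibitor. Compound 1, `C[C@H](NC1=CC(=O)C=C(C(C)(C)C)C1=O)C(=O)O`, is the smaller of the two measured compounds. In this assay compound 1 gives only a limit of the assay, > 200000 nM, and no number. Compound 2, `CC1=CCC[C@H]2[C@](C)(CC3=CC(=O)C=C(NCC(=O)O)C3=O)[C@@H](C)CC[C@]12C`, carries the same substituted ring on a larger bicyclic core. In this assay, among the compounds with values here, compound 2 gives 183000 nM, and this is the only number the set holds. The only other entry belongs to compound 1: the limit of > 200000 nM in this assay, at which 1 of the 2 values shown sits. Compound 2 therefore stands alone as a measured point, with no neighbour to order it against.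

Compound 3, `CC1=CCC[C@H]2[C@](C)(CC3=CC(=O)C=CC3=O)[C@@H](C)CC[C@]12C`, differs from compound 2 in one place: hydrogen in place of (carboxymethyl)amino on a double-bonded ring carbon. Within the data shown here, no step between measured compounds exists here, so the size of this change in this assay cannot be read from the data. The expectation is a step no larger than the scatter, in either direction. Compound 3 is expected to give about 140000 nM in this assay, between 50000 nM and 250000 nM. That estimate means an expected step of a 1.3-fold lower number from compound 2 to compound 3 (0.12 log units; within the scatter).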

Compound 3, half-maximal inhibitory concentration: > 200000 nM
Compound 3: a limit, no number; the forecaster's own chance of this, stated with the estimate: 35%; at least 1.4-fold (0.15 log units) between middle value and limit.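

Putting hydrogen in place of (carboxymethyl)amino on the double-bonded ring carbon does not yield a measurable cytotoxic potency in this assay: compound 3 gives only a limit, > 200000 nM, and no number. The change is read as an at least 1.0-fold higher number from compound 2 to compound 3 (0.03 log units; that floor lies within the scatter), so only a floor for the step is known, and its true size remains undetermined. This position can therefore carry hydrogen without the (carboxymethyl)amino group and still give no number, which leaves compound 2 as the only measured point, with no second number to order it against: the limit of > 200000 nM in this assay, at which 2 of the 3 values shown sit.

Going by these compounds, whether a simple amine, a carboxylic acid or a longer chain on this ring carbon would give a number in this assay remains open. On these data alone, it is also open how far the value of compound 3 lies from the limit, and so whether removing the (carboxymethyl)amino group changes the result by more than the usual scatter of this kind of measurement.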